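Removing the chloro from compound 2

A few compounds are considered here, and "the series" means these few. Any claim that something is new, unique, unknown or untested is made for them only; others in the source may bear on it.

In a functional assay on HCT-116 cells (Homo sapiens) for inhibition, read by CCK-8 assay, with a stated time of 48 h (on this read-out higher numbers stand for weaker inhibition and lower numbers for stronger inhibition), compound 1 (`COc1cc(-c2cc3nccc(-c4cc(OC)c(OC)c(OC)c4)n3n2)cc(OC)c1OC`) gives > 10000 nM as a limit of the assay, not a number. Compound 2 (`COc1cc(-c2ccnc3cc(-c4ccc(Cl)cc4)nn23)cc(OC)c1OC`) gives 3340 nM and compound 3 (`Cn1ccc2cc(-c3cc4nccc(-c5ccc(F)cc5)n4n3)ccc21`) gives 2160 nM in the same read-out. Among the measured compounds shown here, these are the only two numbers so far, and they lie within the scatter of each other. Compound 4 (`COc1cc(-c2ccnc3cc(-c4ccccc4)nn23)cc(OC)c1OC`) has hydrogen in place of chloro on an aromatic carbon, para to a large group (hydrogen in place of chloro on an aromatic carbon). For the measured compounds named here, no measured step shows this change, so no shift beyond the scatter is expected in this assay, with any drift slightly toward a higher number. The estimated step of a 1.2-fold higher number from compound 2 to compound 4 (0.08 log units; within the scatter) is expected to stay small. For compound 4 the expected value is 4000 nM with 1300 nM to 10000 nM as the estimated range.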

Compound 4, half-maximal inhibitory concentration: 3880 nM
Compound 4: the middle estimate sits 1.0-fold (0.01 log units) above what was measured; the range from low to high includes it.
By their numbers in this assay, from the lowest: compounds 3, 2 and 4 (each within the scatter of the next). At a limit, above all of these: compound 1.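

Among the compounds shown here, replacing 4-chlorophenyl with phenyl gives a 1.2-fold higher number from compound 2 to compound 4 (0.07 log units; within the scatter) in this assay, the only measured step at this position. With the trimethoxyphenyl-bearing core of compound 2 held constant, the chloro para to a large group is therefore not needed to keep the number at this level. Compound 1 remains a limit of the assay, not a number: the limit of > 10000 nM in this assay, at which 1 of the 4 values shown sits.

Going by these compounds, whether an amine or a carboxylic acid at this position would move the number beyond the scatter stays open. So does whether removing the chloro has the same small effect in other compounds of the series.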